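The source may report more compounds than this note shows. Statements on the series, on what has been measured and on what is new or still open speak of the compounds shown alone.

Compounds measured in a functional assay on MGC-803 cells (Homo sapiens) for inhibition, read by sulforhodamine B assay; on this read-out higher numbers stand for weaker inhibition and lower numbers for stronger inhibition:
compound 1 `Cc1ccc(NC2=CC(=O)c3nc4n(c3C2=O)[C@H]2OC[C@@H](O)[C@H]2OC4)cc1`, 1420 nM
compound 2 `O=C1C(Nc2cccc(Cl)c2)=CC(=O)c2c1nc1n2[C@H]2OC[C@@H](O)[C@H]2OC1`, 1530 nM
compound 3 `CCc1ccc(NC2=CC(=O)c3nc4n(c3C2=O)[C@H]2OC[C@@H](O)[C@H]2OC4)cc1`, 1290 nM

Compound 2 gives the highest of the three numbers, yet its gaps to compound 1 and to compound 3 both fall within the scatter, so the three compounds cannot be ranked against each other. Compound 4 `CCOc1ccccc1NC1=CC(=O)c2c(nc3n2[C@H]2OC[C@@H](O)[C@H]2OC3)C1=O` differs from compound 2 in one place: 2-ethoxyphenyl in place of 3-chlorophenyl on an amine nitrogen. Among the compounds with values here, the only measured step, a 1.1-fold lower number from compound 1 to compound 3 (0.04 log units; within the scatter), alters a saturated chain carbon elsewhere in the molecule and stayed within the scatter; no measured step replaces the group on the amine nitrogen with one of this kind. Compound 4 is therefore expected to remain close to compound 2, an estimated step of a 1.0-fold lower number from compound 2 to compound 4 (0.01 log units; within the scatter), with wide uncertainty. The estimate for compound 4 is 1500 nM, ranging from 500 nM to 4500 nM.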

Compound 4, half-maximal inhibitory concentration: 2830 nM
Compound 4: the middle estimate sits 1.9-fold (0.28 log units) below what was measured, within the range that was stated.
By their numbers in this assay, from the lowest: compounds 3, 1, 2 and 4 (each within the scatter of the next, the first and the last beyond it).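

Placing 2-ethoxyphenyl in place of 3-chlorophenyl on the amine nitrogen gives, in this assay, a 1.8-fold higher number from compound 2 to compound 4 (0.27 log units; within the scatter). At this position, then, a phenyl group carrying a hydrogen-bond acceptor gives a number that cannot be told apart from that of the chlorinated group. No supporting data bear on this result. Still open, from the compounds shown here alone, is whether a phenyl ring bearing a carboxylic acid or an amine, or a saturated ring on the amine nitrogen, would move the number beyond the scatter.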